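The source may hold more compounds than are shown below. What is called first, only, known or untested is meant among the compounds shown, and "the series" means these compounds.

Measured so far in an ADME assay on MT4 cells (Homo sapiens) for cytotoxicity, read by MTT assay; on this read-out higher numbers stand for lower toxicity in this test and lower numbers for higher toxicity in this test: compound 1 `O=C1c2ccccc2C(=O)N1CCOC(=S)N(C(=O)c1cc(F)ccc1F)c1ccc(Cl)cc1` gives 54000 nM; compound 2 `O=C1c2ccccc2C(=O)N1CCOC(=S)N(C(=O)c1c(F)cccc1F)c1ccc(Cl)cc1` gives 39000 nM; compound 3 `Cc1ccc(N(C(=O)c2cc(F)ccc2F)C(=S)OCCN2C(=O)c3ccccc3C2=O)cc1` gives 62000 nM.

Compound 4 `Cc1ccc(N(C(=O)c2c(F)cccc2F)C(=S)OCCN2C(=O)c3ccccc3C2=O)cc1` has not been measured. It differs from compound 3 in one place: 2,6-difluorophenyl in place of 2,5-difluorophenyl on a carbonyl carbon. The same change is already on record between two measured compounds, since compound 2 differs from compound 1 as follows: 2,6-difluorophenyl in place of 2,5-difluorophenyl on a carbonyl carbon. That change gave a 1.4-fold lower number from compound 1 to compound 2 (0.14 log units; within the scatter). The two cores on which the change is made differ from each other as follows: methyl in place of chloro on an aromatic carbon, and that difference gave a 1.1-fold higher number from compound 1 to compound 3 (0.06 log units; within the scatter). Both changes sit at the same place, so they count as the same change, and all three measured values lie within the scatter of one another.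

On that basis the step from compound 3 to compound 4 in this assay is expected to be a 1.4-fold lower number from compound 3 to compound 4 (0.15 log units; within the scatter), matching the earlier step. Compound 4 is therefore estimated at 44000 nM, with a likely range from 25000 nM to 80000 nM.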

Compound 4, half-maximal cytotoxic concentration: 65000 nM
Compound 4: the middle estimate sits 1.5-fold (0.17 log units) below what was measured; measured number inside the range.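

In this assay, 2,6-difluorophenyl in place of 2,5-difluorophenyl on the carbonyl carbon gives a 1.0-fold higher number from compound 3 to compound 4 (0.02 log units; within the scatter), and this step agrees with the earlier one on the other core: the same change on two cores in this assay, a 1.4-fold lower number (0.14 log units; within the scatter) from compound 1 to compound 2 and a 1.0-fold higher number (0.02 log units; within the scatter) from compound 3 to compound 4, 1.5-fold (0.16 log units) apart, within the scatter of two such steps. Methyl in place of chloro gives a 1.7-fold higher number from compound 2 to compound 4 (0.22 log units; within the scatter), which also agrees with its earlier counterpart: the same change on two cores in this assay, a 1.1-fold higher number (0.06 log units; within the scatter) from compound 1 to compound 3 and a 1.7-fold higher number (0.22 log units; within the scatter) from compound 2 to compound 4, 1.5-fold (0.16 log units) apart, within the scatter of two such steps. Both changes therefore carry across these two cores without a step beyond the scatter, but with steps this small, this does not show a real effect being transferred, nor that the agreement would hold on any other core.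

The compounds shown leave open whether a step beyond the scatter would appear with an amine or a carboxylic acid in place of the chloro or methyl.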